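A few compounds are considered here, and "the series" means these few. Any claim that something is new, unique, unknown or untested is made for them only; others in the source may bear on it.

Of the compounds shown here, two have numbers so far. Compound 1 `COc1cccc(CNCCCNc2ccnc3cc(Oc4ccc(C(C)(C)C)cc4)ccc23)c1O` gives 317 10^-6 cm/s in an ADME assay for permeability, using PAMPA, with a stated time of 30 min, at pH 7.4; a higher number here means that the compound crosses the layer faster, a lower number that the compound crosses the layer more slowly. Compound 2 `COc1ccc(F)cc1CNCCCNc1ccnc2cc(-c3ccc(C(F)(F)F)cc3)ccc12` gives 237 10^-6 cm/s in this assay; the two values of compound 1 and compound 2 lie within the scatter of each other, so compound 2 cannot be placed above or below compound 1 on what is shown.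

Compound 3 `COc1cccc(CNCCCNc2ccnc3cc(-c4ccc(C(F)(F)F)cc4)ccc23)c1O` is not yet measured. Its difference from compound 2 is 2-hydroxy-3-methoxyphenyl in place of 5-fluoro-2-methoxyphenyl on a saturated chain carbon bound to an amine nitrogen. Among the measured compounds shown here, no measured pair shows this exact change on the shared core. Compound 1 carries the same 2-hydroxy-3-methoxybenzyl group as compound 3, though with a different substituent on the other end of the core, and its value sits within the scatter of compound 2. On that ground no step beyond the scatter is expected, in either direction, for a 1.1-fold higher number from compound 2 to compound 3 (0.02 log units; within the scatter). For compound 3 the estimate in this assay is 250 10^-6 cm/s, with a range from 130 10^-6 cm/s to 450 10^-6 cm/s.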

Compound 3, apparent permeability: 237 10^-6 cm/s
Compound 3: middle estimate off by 1.1-fold (0.02 log units), on the high side; measured number inside the range.
By their numbers in this assay, from the lowest: compounds 2, 3 and 1 (each within the scatter of the next).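

In this assay, among the compounds shown here, 2-hydroxy-3-methoxyphenyl in place of 5-fluoro-2-methoxyphenyl on a saturated chain carbon bound to an amine nitrogen gives no change at the digits printed from compound 2 to compound 3 (within the scatter), so this exchange, read here for the first time on the shared core, leaves no step beyond the scatter even though the entering group carries a hydrogen-bond donor that the leaving group lacks. With the 2-hydroxy-3-methoxybenzyl group held fixed, 4-(trifluoromethyl)phenyl in place of 4-(tert-butyl)phenoxy on an aromatic carbon gives a 1.3-fold lower number from compound 1 to compound 3 (0.13 log units; within the scatter), so the second place of variation also shows no step beyond the scatter in this assay. No supporting information bears on why both exchanges leave the read-out within the scatter.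

The exchange at the chain carbon alters the hydroxy, methoxy and fluoro substituents together, so the compounds shown cannot separate the share of each. As far as these compounds go, how this assay responds to a phenyl ring bearing a carboxylic acid or a dimethylamino group, or to a longer chain in place of the present one, remains open.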